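The source may hold more compounds than are shown below. What is called first, only, known or untested is meant among the compounds shown, and "the series" means these compounds.

Working notes on the series, an assay on CHO cells for displacement of a labelled ligand from Alpha-2B adrenergic receptor (Homo sapiens); on this read-out higher numbers stand for weaker inhibition and lower numbers for stronger inhibition.

Among the compounds with values here, compound 2 `CC(Oc1ccccc1-c1cccs1)C1=NCCN1` gives 214 nM in this assay and stands as the lower of the two numbers so far; the nearest neighbour is compound 1 `Cc1cccc(-c2ccccc2OC(C)C2=NCCN2)c1`, which gives 537 nM. Within the data shown here, the only measured step within the pair, a 2.5-fold lower number from compound 1 to compound 2 (0.40 log units; beyond the scatter), is an aryl-for-aryl exchange at the same position of the shared core and lies beyond the scatter, though only modestly so.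

Compound 3 `CC(Oc1ccccc1-c1ccccn1)C1=NCCN1` is not yet measured. It differs from compound 2 in one place: pyridin-2-yl in place of thiophen-2-yl on an aromatic carbon. Among the measured compounds shown here, both the group that leaves and the group that enters are small aromatic rings carrying a single hetero atom and a single hydrogen-bond acceptor, so the change is of a kind with the one already seen, and the one measured step suggests that such exchanges move the number only modestly. For the measured compounds named here, no step in the data bears directly on a five-membered to six-membered ring exchange, so the direction is open.

For compound 3 the estimated number is 320 nM, with an expected range from 120 nM to 850 nM, which corresponds to an expected step of a 1.5-fold higher number from compound 2 to compound 3 (0.17 log units; within the scatter). This expected number would lie close to that of compound 2, within the scatter or barely beyond it.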

Compound 3, inhibition constant: 3310 nM
Compound 3: middle estimate off by 10-fold (1.01 log units), on the low side; the measured number lies above the stated range.
By their numbers in this assay, from the lowest: compound 2; then compound 1; then compound 3.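

Within the data shown here, the position on an aromatic carbon ortho to a group of 8 heavy atoms is far less tolerant in this assay than the first step suggested: the exchange of thiophen-2-yl for pyridin-2-yl gives a 15-fold higher number from compound 2 to compound 3 (1.19 log units; beyond the scatter), a large step, whereas the only earlier step was modest. Both groups count one aromatic ring with 1 hetero atom, 0 hydrogen-bond donors, 1 hydrogen-bond acceptor and no net charge, so these counts do not separate the two; they differ in ring size, heavy-atom count and the identity of the hetero atom. Pyridin-2-yl also compares poorly with 3-methylphenyl, giving a 6.2-fold higher number from compound 1 to compound 3 (0.79 log units; beyond the scatter), so compound 3 now has the highest number of the three, with its steps to both others beyond the scatter.

No measurement at hand accounts for the size of this step.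

The three compounds leave open whether the higher number follows the ring nitrogen, its place in the ring or the six-membered ring itself, a question that pyridin-3-yl, pyridin-4-yl, unsubstituted phenyl and furan-2-yl at the same carbon would help to separate.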